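Swapping the amide for a thioester on the shared core

The source may report more compounds than this note shows. Statements on the series, on what has been measured and on what is new or still open speak of the compounds shown alone.

In an assay on membranes from CHO cells for displacement of a labelled ligand from adenosine receptor A1 (Homo sapiens), read by scintillation counting, with a stated time of 60 min, tested at 1 uM (on this read-out higher numbers stand for more inhibition at the one concentration tested (going by the name of the read-out) and lower numbers for less inhibition), compound 1 `CCCOC(=O)C1=C(C)NC(=O)NC1c1ccsc1` gives 44%, compound 2 `CC1=C(C(=O)OC(C)(C)C)C(c2ccsc2)NC(=O)N1` gives 15% and compound 3 `CCN(CC)C(=O)C1=C(C)NC(=O)NC1c1ccsc1` gives 11%. Compound 3 carries the lowest number of the three, though the difference a number 4 percentage points lower from compound 2 to compound 3 (within the scatter) lies within the scatter, while the step of a number 33 percentage points lower from compound 1 to compound 3 (beyond the scatter) is clearly beyond it. Compound 4 `CC1=C(C(=O)SC(C)C)C(c2ccsc2)NC(=O)N1` differs from compound 3 in one place: isopropylsulfanyl in place of diethylamino on a carbonyl carbon. Within the data shown here, the steps that bear on this change are those at the same carbonyl carbon, a number 33 percentage points lower from compound 1 to compound 3 (beyond the scatter) and a number 4 percentage points lower from compound 2 to compound 3 (within the scatter), which show that the group on that carbon can move the read-out. A modest rise is therefore expected, a number 14 percentage points higher from compound 3 to compound 4 (beyond the scatter). Compound 4 is estimated at 25%, within a range from 8% to 45%.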

Compound 4, a percentage reported as inhibition, at one concentration (the size of the read-out at that concentration, not a potency): 24%
Estimate against measurement, compound 4: 1 percentage points above; measured number inside the range.
By their numbers in this assay, from the lowest: compounds 3, 2 and 4 (each within the scatter of the next, the first and the last beyond it); then compound 1.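

On this carbonyl carbon, the isopropylsulfanyl thioester of compound 4 gives a higher number than the diethylamino amide of compound 3 (a number 13 percentage points higher from compound 3 to compound 4 (beyond the scatter)) but a lower one than the propoxy ester of compound 1 (a number 20 percentage points lower from compound 1 to compound 4 (beyond the scatter)). Against the tert-butoxy ester, the result sets no order between the two groups (a number 9 percentage points higher from compound 2 to compound 4 (within the scatter)). No measurement shown here explains these differences.

From the compounds shown here alone, whether isopropoxy, the oxygen counterpart of isopropylsulfanyl, would give a different number remains open. So does the outcome with a longer chain on the sulfur or with a carboxylic acid at this carbon.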